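A few compounds are considered here, and "the series" means these few. Any claim that something is new, unique, unknown or untested is made for them only; others in the source may bear on it.

Measured compounds:
compound 1 `Nc1nc(NC2CCCCC2)c2ncn(/C=C3/CC3(CO)CO)c2n1`: "not determined" (no result reported)
compound 2 `CCCNc1nc(N)nc2c1ncn2/C=C1/CC1(CO)CO`: "not determined" (no result reported)
compound 3 `Nc1nc(NCc2ccccc2)c2ncn(/C=C3/CC3(CO)CO)c2n1`: > 20000 nM

In an ADME assay on MOLT-3 cells (Homo sapiens) for cytotoxicity, with a stated time of 7 days (on this read-out higher numbers stand for lower toxicity in this test and lower numbers for higher toxicity in this test), compound 3 gives only > 20000 nM, which is a limit of the test and not a number. Compound 1 and compound 2 carry no result in this assay at all, so compound 3 stands by itself, at the edge of the test and with nothing to compare it against: the limit of > 20000 nM in this assay, at which 1 of the 3 values shown sits. The unmeasured compound 4 `COCCOc1nc(N)nc2c1ncn2/C=C1/CC1(CO)CO` differs from compound 3 in one place: 2-methoxyethoxy in place of benzylamino on an aromatic carbon. Among the measured compounds shown here, no step between two measured compounds is available in this assay, so the size of such a change cannot be read from the data. The step that the limit leaves unreadable from compound 3 to compound 4 is expected to be none beyond the scatter. Compound 4 is expected to sit at about 25000 nM in this assay, within a range from 8000 nM to 80000 nM, and it is quite likely that the test again reports only a limit rather than a number for compound 4.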

Compound 4, half-maximal cytotoxic concentration: > 20000 nM
Compound 4 gave a limit, no number; the forecaster's own chance of this, stated with the estimate: 70%; the middle value does not contradict the limit.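

Among the compounds shown here, both results are limits and not numbers, so no step between compound 3 and compound 4 can be read in this assay. The compounds shown leave open how 2-methoxyethoxy and benzylamino compare on the shared core, with the values of both compounds at one limit: the limit of > 20000 nM in this assay, at which 2 of the 4 values shown sit.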